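Opening a Three-Membered Ring on an Amine Chain

The compounds below may be only part of what the source reports. "The series", "measured", "known", "first", "only" and "open" are said of these compounds alone.

Compound 2 `CCCCCC(=O)c1ccc(OCCCN2CCN(CC3CC3)CC2)cc1` was measured in an assay on isolated protein for binding affinity to histamine H2 receptor (Homo sapiens) (a lower number here means a stronger inhibitor, a higher number a weaker inhibitor), and gives 18600 nM in that assay. Its neighbour compound 1 `CCCCCC(=O)c1ccc(OCCCN2CCN(C(=O)CSCC)CC2)cc1` gives 22900 nM in this assay, and since the step of a 1.2-fold lower number from compound 1 to compound 2 (0.09 log units; within the scatter) lies within the scatter, compound 2 stands level with compound 1 on the numbers shown. Compound 3 `CCCCCC(=O)c1ccc(OCCCN2CCN(CCCC)CC2)cc1` differs from compound 2 by propyl in place of cyclopropyl on a saturated chain carbon bound to an amine nitrogen in a ring. Within the data shown here, the single measured step exchanged the group on the ring nitrogen itself, so no measured step bears directly on this change, and in this assay a step of no more than the scatter is expected in either direction. Compound 3 is therefore estimated at 18000 nM with a range from 8000 nM to 40000 nM, which means an expected step of a 1.0-fold lower number from compound 2 to compound 3 (0.01 log units; within the scatter).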

Compound 3, inhibition constant: 7590 nM
The estimate for compound 3 lay 2.4-fold (0.38 log units) above the measured number; the whole stated range lies above it.
By their numbers in this assay, from the lowest: compound 3; then compounds 2 and 1 (each within the scatter of the next).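

In this assay the ring on this saturated chain carbon proves to matter: propyl in place of cyclopropyl gives a 2.5-fold lower number from compound 2 to compound 3 (0.39 log units; beyond the scatter) and so separates two groups with the same heavy-atom count. Butyl in place of ((ethylsulfanyl)methyl)carbonyl on the amine nitrogen in a ring gives a 3.0-fold lower number from compound 1 to compound 3 (0.48 log units; beyond the scatter) and so moves the number where cyclopropylmethyl did not. Nothing available explains why the open chain differs from the ring. From the compounds shown here alone, whether a longer chain such as hexyl would lower the number further remains open, as does the effect of a branched isobutyl group or a terminal hydroxyl on the butyl chain.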